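This account rests on a few compounds, and the source may have more. Where it says the series, first, only, none or still open, it means among the compounds named here.

Working notes on the series. Compound 1 `Cc1ccc(C(=O)Nc2cccc(-c3oc4cc(-c5ccc(F)cc5)ccc4c(=O)c3O)c2)cc1` and compound 2 `Cc1ccccc1C(=O)Nc1cccc(-c2oc3cc(-c4ccc(F)cc4)ccc3c(=O)c2O)c1` share one core and differ only in the aryl group on the amide carbonyl. In a functional assay on GTL 16 cells for antiproliferative activity against GTL 16 cell line (Homo sapiens), read by CCK-8 assay, with a stated time of 72 h (on this read-out lower numbers stand for stronger inhibition and higher numbers for weaker inhibition), compound 1 gives 12900 nM. In this assay compound 2 gives 24800 nM, the highest of the two numbers; the step of a 1.9-fold higher number from compound 1 to compound 2 (0.28 log units; within the scatter) stays within the scatter, so no order between the two compounds is claimed.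

Compound 3 `CCc1ccc(C(=O)Nc2cccc(-c3oc4cc(-c5ccc(F)cc5)ccc4c(=O)c3O)c2)cc1` is the next member. The change from compound 2 is 4-ethylphenyl in place of 2-methylphenyl on a carbonyl carbon. Among the compounds with values here, the one measured step that bears on it is a 1.9-fold higher number from compound 1 to compound 2 (0.28 log units; within the scatter), a 4-methyl to 2-methyl change that stayed within the scatter. Within the data shown here, compound 3 returns the substituent to the 4-position, lengthened by one carbon, for which no measured step exists. Compound 3 is therefore expected to land near compound 1 and within the scatter of compound 2, the step of a 1.8-fold lower number from compound 2 to compound 3 (0.25 log units; within the scatter) being an estimate only. Compound 3 is estimated at 14000 nM, with a range of 5000 nM to 40000 nM.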

Compound 3, half-maximal inhibitory concentration: 24600 nM
Compound 3: middle estimate off by 1.8-fold (0.24 log units), on the low side, within the range that was stated.
By their numbers in this assay, from the lowest: compounds 1, 3 and 2 (each within the scatter of the next).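

In this assay the exchange of 2-methylphenyl for 4-ethylphenyl on the carbonyl carbon gives a 1.0-fold lower number from compound 2 to compound 3 (0.00 log units; within the scatter) and so leaves no readable difference. Within the data shown here, the one added carbon that turns the methyl of compound 1 into the ethyl of compound 3 gives a 1.9-fold higher number from compound 1 to compound 3 (0.28 log units; within the scatter) and also stays within the scatter, which is the first reading of chain length at this position. All three amides now lie within the scatter of one another, so neither the place of the alkyl group on the aryl ring nor the step from methyl to ethyl separates them, and no evidence on the cause is at hand.

Still open, from the compounds shown here alone, is whether an amine, a carboxylic acid or a longer chain on this aryl ring would give a step beyond the scatter. Also open, going by these compounds, is how a saturated ring such as piperidine would read in place of the aryl group.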